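Taking one chlorine off compound 3

The source may report more compounds than this note shows. Statements on the series, on what has been measured and on what is new or still open speak of the compounds shown alone.

Measured in a functional assay on A549 cells (Homo sapiens) for cytotoxicity, read by MTT assay, with a stated time of 48 h (a higher number here means a weaker inhibitor, a lower number a stronger inhibitor), so far:
Compound 1 `CCOC(=O)[C@]1(C(=O)Nc2ccccc2)C[C@@H]1c1cc(OC)c(OC)c(OC)c1` gives 21300 nM
Compound 2 `CCOC(=O)[C@@]1(C(=O)NCc2ccc(C)cc2)C[C@H]1c1cc(OC)c(OC)c(OC)c1` gives 17100 nM
Compound 3 `CCOC(=O)[C@@]1(C(=O)Nc2ccccc2Cl)C[C@H]1c1cc(OC)c(OC)c(OC)c1` gives 17600 nM

These three numbers lie within the usual scatter of one another, so compound 3 stands level with compound 1 and compound 2. Compound 4 (`CCOC(=O)[C@@]1(C(=O)Nc2ccccc2)C[C@H]1c1cc(OC)c(OC)c(OC)c1`) has hydrogen in place of chloro on an aromatic carbon, ortho to a large group (hydrogen in place of chloro on an aromatic carbon). Among the measured compounds shown here, only one measured step bears on this, a swap of 4-methylbenzyl for 2-chlorophenyl on an amide-type nitrogen (a 1.0-fold higher number from compound 2 to compound 3 (0.01 log units; within the scatter)), and it stays within the scatter. No step beyond the scatter is therefore expected in this assay and no direction can be told. The estimated step is small (a 1.1-fold higher number from compound 3 to compound 4 (0.02 log units; within the scatter)). For compound 4 the estimated value is 18500 nM with an expected range from 10000 nM to 32000 nM as the upper end.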

Compound 4, half-maximal inhibitory concentration: 65900 nM
Estimate against measurement, compound 4: 3.6-fold (0.55 log units) below, outside the stated range (above it).
By their numbers in this assay, from the lowest: compounds 2, 3 and 1 (each within the scatter of the next); then compound 4.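

In this assay the chlorine of the 2-chlorophenyl group matters: taking it off gives a 3.7-fold higher number from compound 3 to compound 4 (0.57 log units; beyond the scatter) and so weakens the compound. Phenyl in place of 4-methylbenzyl gives a 3.9-fold higher number from compound 2 to compound 4 (0.59 log units; beyond the scatter) as well, which leaves compound 4 the weakest of the four. Configuration counts too, with a 3.1-fold higher number from compound 1 to compound 4 (0.49 log units; beyond the scatter) for a change in the drawn arrangement alone: the fact that compounds 1 and 4 differ only in the configuration as drawn.

From the compounds shown here alone, whether fluoro or methoxy in the chlorine's place would serve as chloro does stays open, and so does how the mirror image of compound 3 would read.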